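The compounds below may be only part of what the source reports. "The series", "measured", "known", "first", "only" and "open" are said of these compounds alone.

Working notes on the series. In a functional assay on the whole organism (arterial blood) with Rattus norvegicus as the target (on this read-out lower numbers stand for an effect already at smaller amounts and higher numbers for an effect only at larger amounts of compound), compound 3 `Cc1nc2cnccc2n1CC1CCN(C(=O)CCc2ccccc2)CC1` gives > 5 mg/kg, which is a limit and not a number.

Compound 1 `COC(=O)NC(CC(=O)N1CCC(Cn2c(C)nc3cnccc32)CC1)c1ccccc1` carries (methoxycarbonyl)amino in place of hydrogen on a saturated chain carbon bound to an aromatic carbon and a saturated chain carbon, and compound 1 gives 0.035 mg/kg. Compound 2 `CCCC(CC(=O)N1CCC(Cn2c(C)nc3cnccc32)CC1)c1ccccc1` carries propyl at that place, and compound 2 gives 0.0079 mg/kg.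

Compound 4 `CCOC(=O)C(CC(=O)N1CCC(Cn2c(C)nc3cnccc32)CC1)c1ccccc1` has ethoxycarbonyl in place of hydrogen at the same carbon: ethoxycarbonyl in place of hydrogen on a saturated chain carbon bound to an aromatic carbon and a saturated chain carbon.

Among the measured compounds shown here, two measured steps bear most directly on this change: an at least 140-fold higher number from compound 1 to compound 3 (2.15 log units; beyond the scatter) and an at least 630-fold higher number from compound 2 to compound 3 (2.80 log units; beyond the scatter). Both are large and run towards higher numbers when hydrogen replaces the group. The remaining step, a 4.4-fold lower number from compound 1 to compound 2 (0.65 log units; beyond the scatter), is modest and shows that the choice of group also matters. Neither group is ethoxycarbonyl, so the transfer is uncertain, but a large step towards lower numbers is expected in this assay. The estimated step is an at least 120-fold lower number from compound 3 to compound 4 (2.09 log units; beyond the scatter). For compound 4 the estimate is 0.04 mg/kg, with an expected range of 0.007 mg/kg to 0.4 mg/kg.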

Compound 4, dose for 50% inhibition: 0.17 mg/kg
Estimate against measurement, compound 4: 4.3-fold (0.63 log units) below; measured number inside the range.
By their numbers in this assay, from the lowest: compound 2; then compound 1; then compound 4. At a limit, above all of these: compound 3.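

Ethoxycarbonyl at this carbon also gives a large step away from the hydrogen of compound 3 (an at least 29-fold lower number from compound 3 to compound 4 (1.46 log units; beyond the scatter)), so all three groups shown here lower the number relative to hydrogen. The three are not interchangeable: ethoxycarbonyl falls behind propyl by a large step (a 22-fold higher number from compound 2 to compound 4 (1.33 log units; beyond the scatter)) and behind (methoxycarbonyl)amino by a modest one (a 4.9-fold higher number from compound 1 to compound 4 (0.69 log units; beyond the scatter)), which places it last of the three substituted compounds. The step from hydrogen starts at a limit and not a number, so its true size stays unknown: the limit of > 5 mg/kg in this assay, at which 1 of the 4 values shown sits.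

The compounds shown leave open whether a group as small as methyl at this carbon would already give much of the step from hydrogen. They also leave open how a carboxylic acid, an amine or a longer chain such as butyl would compare with propyl.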